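Dipropylamino in place of benzylamino on the aminopyridine nitrogen

The compounds below may be only part of what the source reports. "The series", "measured", "known", "first", "only" and "open" are said of these compounds alone.

Compound 3 `CC(C(=O)NCc1ccc(C(F)(F)F)nc1NCc1ccccc1)c1ccc(NS(C)(=O)=O)c(F)c1` in a functional assay on CHO-K1 cells for antagonist activity at transient receptor potential cation channel subfamily V member 1 (Homo sapiens), read by FLIPR (a higher number here means a weaker inhibitor, a lower number a stronger inhibitor), gives 15.8 nM, the second highest of the three numbers; its nearest neighbour is compound 1 `CCCCNc1nc(C(F)(F)F)ccc1CNC(=O)C(C)c1ccc(NS(C)(=O)=O)c(F)c1` with 9.1 nM, its furthest is compound 2 `CC(C(=O)NCc1ccc(C(F)(F)F)nc1Nc1ccccc1)c1ccc(NS(C)(=O)=O)c(F)c1` with 59.6 nM. Compound 4 `CCCN(CCC)c1nc(C(F)(F)F)ccc1CNC(=O)C(C)c1ccc(NS(C)(=O)=O)c(F)c1` carries dipropylamino in place of benzylamino on an aromatic carbon. Among the measured compounds shown here, two measured steps bear on it: a 1.7-fold higher number from compound 1 to compound 3 (0.24 log units; within the scatter), which shows that a chain and a benzyl group at this position give similar numbers, and a 3.8-fold lower number from compound 2 to compound 3 (0.58 log units; beyond the scatter). For the measured compounds named here, no measured step removes the amine hydrogen, so that part of the change is untested. A small shift is therefore expected, with a 1.4-fold higher number from compound 3 to compound 4 (0.14 log units; within the scatter) as the likely outcome. Compound 4 is estimated at 22 nM, within 7 nM to 70 nM.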

Compound 4, inhibition constant: 0.2 nM
For compound 4 the middle estimate is 110-fold (2.04 log units) above the measured one, and the stated range ends above it.
By their numbers in this assay, from the lowest: compound 4; then compounds 1 and 3 (each within the scatter of the next); then compound 2.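

In this assay dipropylamino, which has no amine hydrogen, separates from all three amines that keep one, with a 79-fold lower number from compound 3 to compound 4 (1.90 log units; beyond the scatter) and a 46-fold lower number from compound 1 to compound 4 (1.66 log units; beyond the scatter) and a 300-fold lower number from compound 2 to compound 4 (2.47 log units; beyond the scatter) all large. This aromatic carbon therefore tolerates far more change than the near match of butylamino and benzylamino suggested. Nothing available accounts for this gain.

The second propyl chain and the loss of the amine hydrogen enter together and stay inseparable here. Dimethylamino or dibutylamino at this carbon would show how far the effect depends on chain length.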